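The source may hold more compounds than are shown below. What is called first, only, known or untested is meant among the compounds shown, and "the series" means these compounds.

The measured compounds and their numbers in a functional assay on PC-3 cells (Homo sapiens) for inhibition, read by sulforhodamine B assay, with a stated time of 72 h (a higher number here means a weaker inhibitor, a lower number a stronger inhibitor), are:

compound 1, `Nc1sc(-c2ccc(Cl)cc2)c(-c2ccc(Cl)cc2)c1C(=O)N1CCCC1`: 6220 nM
compound 2, `Nc1sc(-c2ccc(Cl)cc2)c(-c2ccc(Cl)cc2)c1C(=O)NC1CCCC1`: 21200 nM
compound 3, `COc1ccc(CNC(=O)c2c(N)sc(-c3ccc(Cl)cc3)c2-c2ccc(Cl)cc2)cc1`: 29500 nM

Compound 1 holds the lowest number of the three. Compound 2 is nearest to it, with a 3.4-fold higher number from compound 1 to compound 2 (0.53 log units; beyond the scatter), and compound 3 is furthest, with a 4.7-fold higher number from compound 1 to compound 3 (0.68 log units; beyond the scatter); both steps lie beyond the scatter. Between compound 2 and compound 3 the step is a 1.4-fold higher number from compound 2 to compound 3 (0.14 log units; within the scatter), which lies within the scatter.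

Compound 4, `CC(C)CNC(=O)c1c(N)sc(-c2ccc(Cl)cc2)c1-c1ccc(Cl)cc1`, is reached from compound 1 by isobutylamino in place of pyrrolidin-1-yl on a carbonyl carbon. The two steps that bear on this change are those from compound 1 to compound 2 and from compound 1 to compound 3: in each, the pyrrolidin-1-yl on the carbonyl carbon gives way to a group carrying one hydrogen-bond donor, and each time the number rose by a modest amount. The step from compound 2 to compound 3 shows that exchanging one such group for another changed little. Compound 4 is therefore expected to show a higher number than compound 1, by a step of similar size, a 3.2-fold higher number from compound 1 to compound 4 (0.51 log units; beyond the scatter). The estimate for compound 4 in this assay is 20000 nM, with a range from 8000 nM to 50000 nM.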

Compound 4, half-maximal inhibitory concentration: 13200 nM
Estimate against measurement, compound 4: 1.5-fold (0.18 log units) above; low and high end bracket the measured number.
By their numbers in this assay, from the lowest: compound 1; then compounds 4, 2 and 3 (each within the scatter of the next, the first and the last beyond it).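

In this assay, isobutylamino brings the same 5 heavy atoms as pyrrolidin-1-yl, and still there is a 2.1-fold higher number from compound 1 to compound 4 (0.33 log units; beyond the scatter) with no atoms added, so opening the ring and gaining the amide hydrogen are enough for a step beyond the scatter, and compound 1 stays lowest of the four. The earlier pair of compounds carrying the amide hydrogen gave no sign that the group on the amide-type nitrogen mattered, but there is now a 2.2-fold lower number from compound 3 to compound 4 (0.35 log units; beyond the scatter) and so a difference within that family, while a 1.6-fold lower number from compound 2 to compound 4 (0.21 log units; within the scatter) leaves compound 2 and compound 4 indistinguishable. No measurement shown here offers an explanation for these steps.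

The ring and the amide hydrogen change together in every step away from compound 1, so the compounds shown cannot say which of the two goes with the higher numbers. Diethylamino on the same carbonyl carbon would separate them, as it has no ring and no amide hydrogen, and piperidin-1-yl would show whether the size of the ring counts.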